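Trimming the Thioether of a Nucleoside Transporter Inhibitor

The compounds below may be only part of what the source reports. "The series", "measured", "known", "first", "only" and "open" are said of these compounds alone.

Of the compounds shown here, three have so far been measured in an assay on isolated protein for binding affinity to Equilibrative nucleoside transporter 1 (Homo sapiens); a higher number here means a weaker inhibitor, a lower number a stronger inhibitor. Compound 1 `O=[N+]([O-])c1ccc2c(c1)CN(c1ncnc3c1ncn3[C@@H]1O[C@H](CO)[C@@H](O)[C@H]1O)CC2` gives 5.5 nM. Compound 2 `CSc1ncnc2c1ncn2C1CCCCO1` gives 275000 nM. Compound 3 `Nc1nc(SCc2ccc(Br)cc2)c2ncn([C@@H]3O[C@H](CO)[C@@H](O)[C@H]3O)c2n1` gives 813 nM. Compound 3 therefore stands second among the three: its number lies far above that of compound 1 and far below that of compound 2, both gaps well beyond the scatter. Compound 4 `Nc1nc(SI)c2ncn([C@@H]3O[C@H](CO)[C@@H](O)[C@H]3O)c2n1` has not yet been measured. It differs from compound 3 in one place only: iodo in place of 4-bromobenzyl on a sulfur. Among the measured compounds shown here, no pair of measured compounds differs in just one place, so no measured step tells directly what this change does. The change strips away the whole 4-bromobenzyl group and leaves only an iodo on the sulfur. Compound 2, which also carries only a small group on its sulfur, shows a very high number, although it differs from compound 3 in other places too. Compound 4 is expected to be a weaker binder than compound 3, with an estimated step of a 25-fold higher number from compound 3 to compound 4 (1.39 log units; beyond the scatter) beyond the scatter. For compound 4 the estimated value is 20000 nM, within a range from 2000 nM to 200000 nM.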

Compound 4, half-maximal inhibitory concentration: 81300 nM
Beside the measured number, compound 4's estimate is 4.1-fold (0.61 log units) below it; measured number inside the range.
By their numbers in this assay, from the lowest: compound 1; then compound 3; then compound 4; then compound 2.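

In this assay, among the compounds shown here, the swap gives a 100-fold higher number from compound 3 to compound 4 (2.00 log units; beyond the scatter), the first direct reading of what the group on this sulfur is worth. With the rest of the molecule unchanged, the number depends strongly on what the sulfur carries, so this position is far from indifferent to the swap. Neither 4-bromobenzyl nor iodo counts any hydrogen-bond donors or acceptors or a net charge, so the counted difference lies in the six-membered aromatic ring and the heavy atoms that leave with it.

Still open, as far as these compounds go, is which part of 4-bromobenzyl carries the effect: a plain benzyl, a chlorobenzyl or a simple ethyl on the same sulfur would divide this single large step into smaller pieces. No measurement at hand gives a reason for the size of the step.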